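The source may report more compounds than this note shows. Statements on the series, on what has been measured and on what is new or still open speak of the compounds shown alone.

Measured so far in a functional assay on HT-29 cells (Homo sapiens) for antiproliferative activity, read by sulforhodamine B assay, with a stated time of 48 h; a higher number here means that more compound is tolerated, a lower number that less compound is tolerated:
Compound 1 `Nc1nn(C(=O)Nc2ccc(Cc3ccccc3)cc2)c2ccccc12` gives 56300 nM
Compound 2 `Nc1nn(C(=O)Nc2ccc(Cc3ccccc3)cc2)c2ccc(Cl)cc12` gives 79100 nM

For the measured compounds named here, of the two numbers so far in this assay, compound 2 gives the larger one; its only neighbour is compound 1, and the step of a 1.4-fold higher number from compound 1 to compound 2 (0.15 log units; within the scatter) lies within the scatter, so the two compounds are not separated on these data.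

Compound 3 `Nc1ccc2c(c1)c(N)nn2C(=O)Nc1ccc(Cc2ccccc2)cc1` differs from compound 2 by amino in place of chloro on an aromatic carbon. Going by the values given here, the only measured step that bears on this place is the exchange of hydrogen for chloro, a 1.4-fold higher number from compound 1 to compound 2 (0.15 log units; within the scatter), which stayed within the scatter. Nothing measured here tells how an amino group at this place behaves, so the expectation rests on that one step alone, and no step beyond the scatter is expected in this assay.

The expected change from compound 2 to compound 3 is therefore a 1.3-fold lower number from compound 2 to compound 3 (0.12 log units; within the scatter). For compound 3 the estimate in this assay is 60000 nM, with a range of 25000 nM to 150000 nM.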

Compound 3, concentration lethal to 50% of the cells: 46000 nM
For compound 3 the middle estimate is 1.3-fold (0.12 log units) above the measured one; the measured number falls inside the stated range.
By their numbers in this assay, from the lowest: compounds 3, 1 and 2 (each within the scatter of the next).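

In this assay, the amino group enters on the aromatic carbon where hydrogen and chloro were already compared, and it brings a hydrogen-bond donor and a hydrogen-bond acceptor that chloro lacks. Neither new step leaves the scatter: a 1.7-fold lower number from compound 2 to compound 3 (0.24 log units; within the scatter) and a 1.2-fold lower number from compound 1 to compound 3 (0.09 log units; within the scatter). All three groups at this place therefore now stand within the scatter of each other, so on these data the exchange of hydrogen, chloro and amino does not separate the compounds. No supporting data bear on this result.

On these data alone, whether a carboxylic acid, a methoxy group or a longer chain at this place would give a step beyond the scatter remains open. So does whether changes elsewhere on the shared core would separate compounds in this assay.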